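The source may report more compounds than this note shows. Statements on the series, on what has been measured and on what is new or still open speak of the compounds shown alone.

Measured compounds:
Compound 1, `O=c1[nH]cc(S(=O)(=O)Nc2ccccc2-c2cn(-c3ccccc3)nn2)c(=O)[nH]1`: in an ADME assay on L02 cells (Homo sapiens) for cytotoxicity, read by MTT assay, with a stated time of 24 h (a lower number here means that less compound is tolerated, a higher number that more compound is tolerated), compound 1 gives 10600 nM.
Compound 2, `Cc1ccc(-n2cc(-c3ccccc3NS(=O)(=O)c3c[nH]c(=O)[nH]c3=O)nn2)cc1`: in this assay compound 2 gives only the assay limit, > 100000 nM.

Compound 2 therefore stands at the upper edge of what these measurements can show; its value is a limit and not a number, and it is the one that sits at the limit of > 100000 nM in this assay, at which 1 of the 2 values shown sits. Among the compounds with values here, the single measured step leading to it is an at least 9.4-fold higher number from compound 1 to compound 2 (0.97 log units; beyond the scatter), which is beyond the scatter.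

Compound 3, `O=c1[nH]cc(S(=O)(=O)Nc2ccccc2-c2cn(-c3ccccc3F)nn2)c(=O)[nH]1`, has not yet been measured in this assay. It differs from compound 2 in one place: 2-fluorophenyl in place of 4-methylphenyl on an aromatic nitrogen. The methyl whose entry carried the step from compound 1 to compound 2 is gone, and a fluorine stands on the ring instead. Within the data shown here, the only measured step that bears on this change is an at least 9.4-fold higher number from compound 1 to compound 2 (0.97 log units; beyond the scatter), a step of at least modest size. Compound 3 is expected to sit below the limit of compound 2, with a number that falls between the two measured compounds. The step that this expectation means is an at least 3.3-fold lower number from compound 2 to compound 3 (0.52 log units; beyond the scatter). The estimate for compound 3 in this assay is 30000 nM, with a range from 8000 nM to 100000 nM.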

Compound 3, half-maximal cytotoxic concentration: > 100000 nM
Compound 3: only a limit was reported; the forecaster's own chance of this, stated with the estimate: 35%; at least 3.3-fold (0.52 log units) between middle value and limit.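

Within the data shown here, a fluorine on the phenyl group gives an at least 9.4-fold higher number from compound 1 to compound 3 (0.97 log units; beyond the scatter), so the methyl of compound 2 is not the only single change on this ring that lifts the number clear of compound 1, whose step was an at least 9.4-fold higher number from compound 1 to compound 2 (0.97 log units; beyond the scatter). In this assay compound 3 gives > 100000 nM, which is a limit of the assay and not a number. The change from 4-methylphenyl to 2-fluorophenyl on the aromatic nitrogen therefore cannot be read as a step in either direction, because both compounds stand at the same edge of the assay: the limit of > 100000 nM in this assay, at which 2 of the 3 values shown sit.

Going by these compounds, how much compound is actually tolerated for compound 2 and compound 3 remains open, and so does any order between them, as neither has a value inside the range of the assay. It is also open whether any substituent on this phenyl group would do the same, since the shown set holds only methyl and fluoro, and a group such as an amine or a carboxylic acid in their place could leave the number close to that of compound 1 or lift it as well.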